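Swapping the amide aryl group in a cytotoxicity series

This account rests on a few compounds, and the source may have more. Where it says the series, first, only, none or still open, it means among the compounds named here.

Measured so far in an ADME assay on HCT-116 cells (Homo sapiens) for cytotoxicity, read by MTT assay, with a stated time of 72 h; on this read-out lower numbers stand for stronger inhibition and higher numbers for weaker inhibition:
compound 1, `COc1ccc(NC(=O)c2cccc(/C=C3\CC(=O)N(c4ccccc4)C3=O)c2)c(C)c1`: > 100000 nM.
compound 2, `COc1cc(NC(=O)c2cccc(/C=C3\CC(=O)N(c4ccccc4)C3=O)c2)cc(OC)c1OC`: > 100000 nM.

For compound 1 the reading > 100000 nM is a limit of the assay, not a number. For compound 2 the reading > 100000 nM is likewise a limit. Compound 1 thus sits at the limit of > 100000 nM in this assay, at which 2 of the 2 values shown sit, with no numeric value to rank it. Compound 3, `CSc1cccc(NC(=O)c2cccc(/C=C3\CC(=O)N(c4ccccc4)C3=O)c2)c1`, is not yet measured and differs from compound 1 by 3-(methylsulfanyl)phenyl in place of 4-methoxy-2-methylphenyl on an amide-type nitrogen. Given (the limit of > 100000 nM in this assay, at which 2 of the 2 values shown sit), the expected step of a number no higher from compound 1 to compound 3 (the limit leaves the size open) is none beyond the scatter. Compound 3 is expected near 100000 nM, between 30000 nM and 300000 nM, most likely reported again as a limit.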

Compound 3, half-maximal inhibitory concentration: 65200 nM
Estimate against measurement, compound 3: 1.5-fold (0.19 log units) above; low and high end bracket the measured number.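

Placing 3-(methylsulfanyl)phenyl in place of 4-methoxy-2-methylphenyl on the amide-type nitrogen gives an at least 1.5-fold lower number from compound 1 to compound 3 (0.18 log units; that floor lies within the scatter). On these data alone, that floor alone shows no clear gain, and the real size of the step stays unknown. Still, this position can carry a group that yields a number rather than a limit, unlike the other compounds shown: the limit of > 100000 nM in this assay, at which 2 of the 3 values shown sit.

Whether the sulfur atom or the overall change in the aryl group accounts for the number remains open. So does the reading with a phenyl ring carrying an amine or a carboxylic acid in this place.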